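Fluorophenyl isomers: from compound 3 to compound 4

The source may hold more compounds than are shown below. What is called first, only, known or untested is meant among the compounds shown, and "the series" means these compounds.

In a functional assay on MCF7 cells (Homo sapiens) for cytotoxicity, read by sulforhodamine B assay, with a stated time of 48 h (on this read-out higher numbers stand for weaker inhibition and lower numbers for stronger inhibition), compound 3 (`COc1ccc(/C=C/C(=O)c2cccc(-c3cccc(F)c3)c2)cc1OC`) gives 4620 nM and holds the lowest of the two numbers available. Compound 1 (`COc1ccc(/C=C/C(=O)c2cccc(-c3ccc(F)cc3)c2)cc1`) gives 16400 nM and lies higher by more than the usual scatter. Compound 2 (`COc1ccc(/C=C/C(=O)c2cccc(Br)c2)cc1OC`) has the entry "not determined" (no result reported) and adds no number. Compound 4 (`COc1ccc(/C=C/C(=O)c2cccc(-c3ccc(F)cc3)c2)cc1OC`) has 4-fluorophenyl in place of 3-fluorophenyl on an aromatic carbon. Compound 1 also carries 4-fluorophenyl, on a different core, and its 16400 nM suggests a small rise rather than a fall. The expected change is a 1.4-fold higher number from compound 3 to compound 4 (0.15 log units; within the scatter) and is estimated to stay within the scatter. For compound 4 the estimate is 6500 nM with an expected range from 2500 nM to 16000 nM in this assay as the read-out.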

Compound 4, half-maximal inhibitory concentration: 11600 nM
Compound 4: the middle estimate sits 1.8-fold (0.25 log units) below what was measured; the range from low to high includes it.
By their numbers in this assay, from the lowest: compound 3; then compounds 4 and 1 (each within the scatter of the next).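

In this assay the swap of 3-fluorophenyl for 4-fluorophenyl gives a 2.5-fold higher number from compound 3 to compound 4 (0.40 log units; beyond the scatter) on the shared core, so this position distinguishes the two isomers, and 3-fluorophenyl gives the lower number. With 4-fluorophenyl in place, the methoxy change elsewhere gives a 1.4-fold lower number from compound 1 to compound 4 (0.15 log units; within the scatter) and so does not separate those two compounds. No measured evidence accounts for the gap between the isomers.

Open, on these data alone, is what an amine or a carboxylic acid on the added phenyl ring would give in place of fluorine. Also open, as far as these compounds go, is whether the isomer gap holds on the core of compound 1.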